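Adding a methyl to compound 2: working notes

The source may report more compounds than this note shows. Statements on the series, on what has been measured and on what is new or still open speak of the compounds shown alone.

Measured in a functional assay on L1210 cells (Mus musculus), with a stated time of 2 days; on this read-out higher numbers stand for weaker inhibition and lower numbers for stronger inhibition:
- compound 1 `C=C1[C@H](O)[C@H](O)CO[C@@H]1n1ccc(O)nc1=O`: > 800000 nM
- compound 2 `O=C1C=CCO[C@@H]1n1ccc(O)nc1=O`: 92000 nM

Compound 1 gives > 800000 nM, which is a limit of the assay and not a number. Among the compounds with values here, that leaves compound 2, at 92000 nM, as the only actual number so far. Compound 3 `Cc1cn([C@H]2OCC=CC2=O)c(=O)nc1O` differs from compound 2 by methyl in place of hydrogen on an aromatic carbon, a methyl in place of hydrogen on an aromatic carbon. Within the data shown here, no measured step covers this change, so no shift beyond the usual scatter is expected in this assay, and neither direction is favoured. The estimated change is a 1.2-fold lower number from compound 2 to compound 3 (0.06 log units; within the scatter). For compound 3 the estimated value is 80000 nM, with an expected range of 25000 nM to 250000 nM.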

Compound 3, half-maximal inhibitory concentration: 34000 nM
Beside the measured number, compound 3's estimate is 2.4-fold (0.37 log units) above it; low and high end bracket the measured number.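

In this assay the aromatic carbon ortho to the hydroxy group and two atoms from the ring nitrogen proves sensitive to substitution: methyl in place of hydrogen there gives a 2.7-fold lower number from compound 2 to compound 3 (0.43 log units; beyond the scatter). Within the data shown here, this is the first step that can be read, and it shows that one added carbon on this ring is enough to move the number, though the step is modest.

Going by these compounds, whether an ethyl, an amine or a chlorine atom on the same carbon would move the number further stays open, as does whether methyl gives a similar step on the core of compound 1. Nothing shown bears on why the number moves.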